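This account rests on a few compounds, and the source may have more. Where it says the series, first, only, none or still open, it means among the compounds named here.

Compound 2 `Cc1ccc2occ([C@@H]3[C@H]4C(=O)N(c5ccccc5)C(=O)[C@H]4ON3c3ccccc3)c(=O)c2c1` carries a methyl on an aromatic carbon of the shared core. In a functional assay on A549 cells (Homo sapiens) for inhibition, read by sulforhodamine B assay, with a stated time of 48 h (a lower number here means a stronger inhibitor, a higher number a weaker inhibitor), compound 2 reaches only the limit of the assay, > 60000 nM. Compound 1 `O=C1[C@H]2[C@H](ON(c3ccccc3)[C@@H]2c2coc3ccc(F)cc3c2=O)C(=O)N1c1ccccc1` carries fluoro at that place, and in this assay compound 1 gives 13500 nM. The step of an at least 4.4-fold higher number from compound 1 to compound 2 (0.64 log units; beyond the scatter) is bounded by the limit of > 60000 nM in this assay, at which 1 of the 2 values shown sits. Compound 3 `O=C1[C@H]2[C@H](ON(c3ccccc3)[C@@H]2c2coc3ccc(Br)cc3c2=O)C(=O)N1c1ccccc1` differs from compound 2 by bromo in place of methyl on an aromatic carbon. Only the fluoro-to-methyl step bears on this change; bromo returns to a halogen, so a number below that of compound 2 is expected, though not as low as compound 1. Compound 3 is expected to give 30000 nM, within 10000 nM to 90000 nM, an expected step of an at least 2.0-fold lower number from compound 2 to compound 3 (0.30 log units; that floor lies within the scatter).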

Compound 3, half-maximal inhibitory concentration: 17000 nM
Compound 3: middle estimate off by 1.8-fold (0.25 log units), on the high side; the measured number falls inside the stated range.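

In this assay bromo in place of fluoro gives a 1.3-fold higher number from compound 1 to compound 3 (0.10 log units; within the scatter) and so these two halogens are not told apart at this position. Bromo in place of methyl gives an at least 3.5-fold lower number from compound 2 to compound 3 (0.54 log units; beyond the scatter) and so the weaker reading with methyl is not shared by either halogen shown. From the compounds shown here alone, the true size of that step stays unknown, since compound 2 stands only at a limit: the limit of > 60000 nM in this assay, at which 1 of the 3 values shown sits. Going by these compounds, whether an amine, a methoxy group or a carboxylic acid at this place reads like the two halogens or like methyl stays open.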